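The source may report more compounds than this note shows. Statements on the series, on what has been measured and on what is new or still open speak of the compounds shown alone.

Measured compounds:
- compound 1 `CC#CC(CC(=O)O)c1ccc(OC2CCCC2)cc1` — 114 nM
- compound 2 `CC#CC(c1ccc(OCc2ccccc2)cc1)C1OC(=O)NC1=O` — 954 nM

In a functional assay on CHO cells for agonist activity at Free fatty acid receptor 1 (Homo sapiens), read by FLIPR and calcium flux (a higher number here means that more compound is needed for the effect, a lower number that less compound is needed), compound 1 gives 114 nM, the lower of the two numbers. Within the data shown here, compound 2 gives 954 nM, a gap beyond the scatter; compound 2 differs from compound 1 in more than one place, so no single step is drawn between them and the two values are only noted as they stand.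

Compound 3 `CC#CC(CC(=O)O)c1ccc(Oc2ncc(Br)cn2)cc1` is not yet measured. It differs from compound 1 by 5-bromopyrimidin-2-yl in place of cyclopentyl on an oxygen on an aromatic ring. Among the measured compounds shown here, no measured pair isolates this kind of exchange, so there is no step to lean on. The step of a 1.3-fold higher number from compound 1 to compound 3 (0.12 log units; within the scatter) is expected to be small, of uncertain direction, and quite possibly none beyond the scatter. Compound 3 is therefore expected to give about 150 nM in this assay, with a plausible range from 40 nM to 600 nM.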

Compound 3, half-maximal effective concentration: 1570 nM
Beside the measured number, compound 3's estimate is 10-fold (1.02 log units) below it; measured number above the stated range.
By their numbers in this assay, from the lowest: compound 1; then compounds 2 and 3 (each within the scatter of the next).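

In this assay, among these compounds, 5-bromopyrimidin-2-yl in place of cyclopentyl on an oxygen on an aromatic ring gives a 14-fold higher number from compound 1 to compound 3 (1.14 log units; beyond the scatter), the first step that isolates a change in one place. The group on this oxygen is therefore not interchangeable: with the rest of compound 1 kept, this exchange alone is enough for a large move towards needing more compound. No measurement at hand accounts for the size of this step.

The compounds shown leave open which part of the entering group carries the step, since the ring, its two nitrogens and the bromine all change together. Pyrimidin-2-yl without the bromine, or plain phenyl on the same oxygen, would separate these contributions.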